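A few compounds are considered here, and "the series" means these few. Any claim that something is new, unique, unknown or untested is made for them only; others in the source may bear on it.

Two members of the series carry the same core and differ only at the aryl group on the saturated ring carbon and in the urea or thiourea part. Compound 1 `COc1cc(/C=C/C(=O)C2=C(/C=C/c3ccc(O)c(OC)c3)NC(=O)NC2c2cccc([N+](=O)[O-])c2)ccc1O` and compound 2 `COc1cc(/C=C/C(=O)C2=C(/C=C/c3ccc(O)c(OC)c3)NC(=S)NC2c2ccccc2O)ccc1O` have both been measured in a functional assay, with a stated time of 20 min, tested at 10 uM; on this read-out lower numbers stand for a weaker effect and higher numbers for a stronger effect at the one concentration tested. In this assay compound 1 gives 51.2% and compound 2 gives 60.2%. Compound 2 has the higher of the two numbers, but the gap to compound 1 lies within the scatter of repeated measurements, so the two cannot be told apart on these numbers. For the measured compounds named here, no step between measured compounds has been worked out, so nothing shows how the aryl substituent alone moves the read-out.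

Compound 3 `COc1cc(/C=C/C(=O)C2=C(/C=C/c3ccc(O)c(OC)c3)NC(=S)NC2c2ccccc2Cl)ccc1O` has not yet been measured in this assay. Compared with compound 2 it differs in one place (chloro in place of hydroxy on an aromatic carbon), the change sitting on a six-membered aromatic ring of carbon only. Going by the values given here, with no measured step to draw on, the step expected a number 5.2 percentage points lower from compound 2 to compound 3 (within the scatter) is none beyond the scatter. Compound 3 is accordingly expected to give about 55%, with a range from 35% to 75%.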

Compound 3, a percentage reported as activity, at one concentration (the size of the read-out at that concentration, not a potency): 43.2%
Compound 3: middle estimate off by 11.8 percentage points, on the high side, within the range that was stated.
By their numbers in this assay, from the lowest: compounds 3, 1 and 2 (each within the scatter of the next, the first and the last beyond it).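

In this assay, for the compounds shown here, 2-hydroxyphenyl to 2-chlorophenyl gives a number 17 percentage points lower from compound 2 to compound 3 (beyond the scatter), with the thiourea part and the rest of the shared core unchanged, so this is the first change that can be read at a single place. It shows that the group on this aromatic carbon, ortho to a large group, matters to the read-out: the read-out of this pair moves beyond the scatter when hydroxy, with one hydrogen-bond donor and one hydrogen-bond acceptor, gives way to chloro, with neither. Nothing measured on these compounds bears on what lies behind this step.

From the compounds shown here alone, one pair cannot separate the loss of hydroxy from the arrival of chloro, and whether a methoxy or an amine at this place would read closer to compound 2 or to compound 3 stays open. Also open, going by these compounds, is whether the same change gives a step of similar size when the urea part found in compound 1 stands in place of the thiourea part.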